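A few compounds are considered here, and "the series" means these few. Any claim that something is new, unique, unknown or untested is made for them only; others in the source may bear on it.

Compound 3 `O=C(NCc1ccccc1)Oc1ccccc1C(=O)Nc1ccccc1` is measured in an ADME assay on HepG2 cells (Homo sapiens), read by MTT assay, with a stated time of 72 h, in the presence of a further agent that is not named here (on this read-out higher numbers stand for weaker inhibition and lower numbers for stronger inhibition), at 54300 nM, the highest of the three numbers in hand. Compound 1 `O=C(Nc1ccccc1)Oc1ccc(Cl)cc1C(=O)Nc1ccc(Br)cc1` gives 5450 nM in this assay, and compound 2 `O=C(Nc1ccccc1)Oc1ccc(Cl)cc1C(=O)Nc1ccc(Cl)cc1` gives 900 nM. For the measured compounds named here, the single step between compounds that differ in one place, a 6.1-fold lower number from compound 1 to compound 2 (0.78 log units; beyond the scatter), concerns a halogen swap on an aromatic carbon and leaves the rest of the molecule untouched.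

Compound 4 `O=C(NC1CCCCC1)Oc1ccccc1C(=O)Nc1ccccc1` differs from compound 3 at the amide-type nitrogen whose other neighbour is a carbonyl carbon: cyclohexyl in place of benzyl on an amide-type nitrogen. Going by the values given here, no measured pair varies that side of the molecule, so the step from compound 1 to compound 2 does not bear on this change, and the data offer no direction for it. With nothing to indicate a shift, the step is expected to stay within the scatter, a 1.1-fold lower number from compound 3 to compound 4 (0.04 log units; within the scatter), though the range must be wide. Compound 4 is therefore estimated at 50000 nM, with a plausible span from 15000 nM to 150000 nM.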

Compound 4, half-maximal inhibitory concentration: 51500 nM
Compound 4: middle estimate off by 1.0-fold (0.01 log units), on the low side; measured number inside the range.
By their numbers in this assay, from the lowest: compound 2; then compound 1; then compounds 4 and 3 (each within the scatter of the next).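

In this assay, cyclohexyl in place of benzyl on an amide-type nitrogen gives a 1.1-fold lower number from compound 3 to compound 4 (0.02 log units; within the scatter), so at this place a non-aromatic ring of carbon and a benzyl group cannot be told apart in this pair. For the compounds shown here, the earlier step, a 6.1-fold lower number from compound 1 to compound 2 (0.78 log units; beyond the scatter), was a swap of halogens on an aromatic carbon and gave no reading of this position, which now shows a first change that stays within the scatter. Nothing at hand offers an explanation for this result.

Going by these compounds, it remains open whether the same holds for a group of another kind on this nitrogen, such as a longer chain, an amine or a carboxylic acid. On these data alone, it also remains open whether the cyclohexyl for benzyl result would carry over to the halogen-bearing core of compound 1 and compound 2.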